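A few compounds are considered here, and "the series" means these few. Any claim that something is new, unique, unknown or untested is made for them only; others in the source may bear on it.

Measured in a functional assay on HeLa cells (Homo sapiens) for inhibition, read by MTT assay; a higher number here means a weaker inhibitor, a lower number a stronger inhibitor:
compound 1 `CCCCCCCCn1cc(/C=C/C(=O)c2ccc(NC(=O)CN3CCN(c4ccccc4F)CC3)cc2)nn1` — compound 1 gives 33800 nM
compound 2 `CCCCCCCCn1cc(/C=C/C(=O)c2ccc(NC(=O)CN3CCN(c4ccccc4OC)CC3)cc2)nn1` — compound 2 gives 26800 nM
compound 3 `CCCCCCCCn1cc(/C=C/C(=O)c2ccc(NC(=O)CN3CCN(c4ccc([N+](=O)[O-])cc4)CC3)cc2)nn1` — compound 3 gives 30200 nM

Among the compounds with values here, compound 3 sits with the other two: a 1.1-fold lower number from compound 1 to compound 3 (0.05 log units; within the scatter) and a 1.1-fold higher number from compound 2 to compound 3 (0.05 log units; within the scatter), just as a 1.3-fold lower number from compound 1 to compound 2 (0.10 log units; within the scatter); no pair of the three values is separated beyond the scatter.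

Compound 4 `CCCCCCCCn1cc(/C=C/C(=O)c2ccc(NC(=O)CN3CCN(C(=O)OC(C)(C)C)CC3)cc2)nn1` is the next member. Change from compound 3: tert-butoxycarbonyl in place of 4-nitrophenyl on an amine nitrogen in a ring. All three measured steps exchange one aromatic group for another on the same ring nitrogen and all stay within the scatter; none exchanges the aromatic group for a group without a ring, so they bear on the present step only loosely. They do show that three different groups at this place left the number unchanged beyond the scatter. Compound 4 is therefore expected to give 30000 nM, within a range of 12000 nM to 75000 nM. The expected step is a 1.0-fold lower number from compound 3 to compound 4 (0.00 log units; within the scatter), within the scatter, with a wider range than usual to reflect the untested kind of change.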

Compound 4, half-maximal inhibitory concentration: 32100 nM
For compound 4 the middle estimate is 1.1-fold (0.03 log units) below the measured one; the range from low to high includes it.
By their numbers in this assay, from the lowest: compounds 2, 3, 4 and 1 (each within the scatter of the next).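

In this assay tert-butoxycarbonyl, a group with no ring, on the amine nitrogen in the ring gives a number level with those of the aromatic groups (a 1.1-fold higher number from compound 3 to compound 4 (0.03 log units; within the scatter)) (a 1.2-fold higher number from compound 2 to compound 4 (0.08 log units; within the scatter)) (a 1.1-fold lower number from compound 1 to compound 4 (0.02 log units; within the scatter)), and all three steps lie within the scatter. Across these four compounds, an aromatic ring at this place is therefore not needed to keep the number where it stands. No measurement on hand accounts for this flat result.

Still open, on these data alone, is whether a free ring amine, an acetyl group or a carboxylic acid at this place would move the number beyond the scatter.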